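Trifluoromethyl to fluoro, repeated on a second core

This account rests on a few compounds, and the source may have more. Where it says the series, first, only, none or still open, it means among the compounds named here.

Three compounds were measured in a functional assay on SMMC-7721 cells (Homo sapiens) for cytotoxicity, read by MTT assay, with a stated time of 24 h; a lower number here means a stronger inhibitor, a higher number a weaker inhibitor:

Compound 1, `O=C1/C(=C/c2ccccc2F)CN(S(=O)(=O)c2ccc(C(F)(F)F)cc2)C/C1=C\c1ccccc1F`, gives 5200 nM.
Compound 2, `O=C1/C(=C/c2ccccc2F)CN(S(=O)(=O)c2ccc(F)cc2)C/C1=C\c1ccccc1F`, gives 7700 nM.
Compound 3, `O=C1/C(=C/c2ccc(F)cc2)CN(S(=O)(=O)c2ccc(C(F)(F)F)cc2)C/C1=C\c1ccc(F)cc1`, gives 4400 nM.

Compound 1 and compound 2 share one core and differ in a single place: fluoro in place of trifluoromethyl on an aromatic carbon. In this assay this change made a 1.5-fold higher number from compound 1 to compound 2 (0.17 log units; within the scatter).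

Compound 3 stands on a different core. Its structure has the same atoms as compound 1 joined differently, and the difference between the two cores is not broken down here. What can be said is that compound 3 and compound 1 give values in this assay that lie close to each other, and that compound 2 does not stand far from either.

Compound 4, `O=C1/C(=C/c2ccc(F)cc2)CN(S(=O)(=O)c2ccc(F)cc2)C/C1=C\c1ccc(F)cc1`, has not yet been measured. It differs from compound 3 in one place: fluoro in place of trifluoromethyl on an aromatic carbon. Among the measured compounds shown here, this is the same change as the one from compound 1 to compound 2, and the surroundings of the place read the same in both pairs.

For compound 4 the step from compound 3 is expected to be a 1.5-fold higher number from compound 3 to compound 4 (0.17 log units; within the scatter) in this assay, because the same change gave a 1.5-fold higher number from compound 1 to compound 2 (0.17 log units; within the scatter) on the first core. On that basis compound 4 is estimated to give 6500 nM in this assay, with a likely range from 3500 nM to 13000 nM. The estimate rests on a single earlier step and on two cores only, so it carries the uncertainty of that small base.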

Compound 4, half-maximal inhibitory concentration: 14700 nM
The estimate for compound 4 lay 2.3-fold (0.35 log units) below the measured number; the whole stated range lies below it.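

In this assay, the change from 4-(trifluoromethyl)phenyl to 4-fluorophenyl on the second core gave a 3.3-fold higher number from compound 3 to compound 4 (0.52 log units; beyond the scatter), and set beside the step on the first core, the two do not differ by more than repeated measurements of this kind would allow: the same change on two cores in this assay, a 1.5-fold higher number (0.17 log units; within the scatter) from compound 1 to compound 2 and a 3.3-fold higher number (0.52 log units; beyond the scatter) from compound 3 to compound 4, 2.3-fold (0.35 log units) apart, within the scatter of two such steps

Carrying the change from one core to the other is therefore compatible with a single shared step, and the number went up in both pairs, although only the step on the second core stands clear of the scatter by itself. Two pairs on two cores do not fix the size of that step, however, and they cannot show that it would hold on any further core or that the two cores respond in exactly the same way.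

The compounds shown leave open what an amine, a carboxylic acid, a nitrile or a methoxy group would give at the aromatic carbon that carries trifluoromethyl or fluoro here. They also leave open whether the same change would read alike on a core with a chlorine or a methyl group in place of the fluoro on the two outer aromatic rings.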